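This account rests on a few compounds, and the source may have more. Where it says the series, first, only, none or still open, it means among the compounds named here.

Measured compounds, inhibition in a functional assay on cells (T-cell, Homo sapiens) for inhibition; a higher number here means a weaker inhibitor, a lower number a stronger inhibitor:
- compound 1, `COc1ccc(-c2cnc3nc(N)nc(N4CCN(C(=O)NCc5ccccc5)CC4)c3n2)cc1OC`: 18 nM
- compound 2, `COc1ccc(-c2cnc3nc(N)nc(N4CCN(C(=O)Nc5cccc(C)c5)CC4)c3n2)cc1OC`: 7 nM
- compound 3, `CCOc1nc(N)nc2ncc(-c3cccc(OC)c3)nc12`: 8300 nM

Among these three numbers compound 1 stands second highest. Its nearest neighbour is compound 2, reached by a 2.6-fold lower number from compound 1 to compound 2 (0.41 log units; beyond the scatter); compound 3, which differs from compound 1 in more than one place, gives a number far above both, and nothing finer can be read from that pair.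

Compound 4, `COc1ccc(-c2cnc3nc(N)nc(N4CCN(C(=O)Nc5ccc(C#N)cc5)CC4)c3n2)cc1OC`, is the next member. Its difference from compound 1: 4-cyanophenyl in place of benzyl on an amide-type nitrogen.

Within the data shown here, only one measured step bears on this change: from compound 1 to compound 2 an aromatic ring was likewise put directly on the amide-type nitrogen in place of benzyl, and that step was a 2.6-fold lower number from compound 1 to compound 2 (0.41 log units; beyond the scatter). Among the measured compounds shown here, compound 4 carries a different substituent on the ring, and no measured pair shows the nitrile itself, so the direction is taken from compound 2 but the size is held loosely. The expected step for compound 4 is thus a 2.0-fold lower number from compound 1 to compound 4 (0.30 log units; within the scatter). Compound 4 is therefore estimated at 9 nM in this assay, within 3 nM to 30 nM.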

Compound 4, half-maximal inhibitory concentration: 74 nM
The estimate for compound 4 lay 8.2-fold (0.91 log units) below the measured number; the whole stated range lies below it.
By their numbers in this assay, from the lowest: compound 2; then compound 1; then compound 4; then compound 3.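

In this assay, an aromatic ring placed directly on the amide-type nitrogen does not by itself give a lower number: 4-cyanophenyl in place of benzyl gives (a 4.1-fold higher number from compound 1 to compound 4 (0.61 log units; beyond the scatter)), against the direction seen with 3-methylphenyl (a 2.6-fold lower number from compound 1 to compound 2 (0.41 log units; beyond the scatter)). The substituted ring at this position therefore counts for a large part of the outcome, with (an 11-fold higher number from compound 2 to compound 4 (1.02 log units; beyond the scatter)) on exchanging 3-methylphenyl for 4-cyanophenyl. No measurement on hand accounts for this reversal.

The compounds shown leave open whether the gap between compound 2 and compound 4 follows the nitrile itself or where the substituent sits on the ring. Also open, going by these compounds, is how plain phenyl on the same nitrogen, or a ring bearing an amine or a carboxylic acid, would compare.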